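The compounds below may be only part of what the source reports. "The series", "measured", "known", "first", "only" and "open" are said of these compounds alone.

Working notes on the series. In an ADME assay on HEK293 cells (Homo sapiens) for cytotoxicity, with a stated time of 72 h (a lower number here means that less compound is needed, a higher number that more compound is needed for the effect), compound 1 (`Cc1cc(NC(=O)Nc2ccccc2OC(F)(F)F)c2ccccc2n1`) gives > 25000 nM as a limit of the assay, not a number. Compound 2 (`Cc1cc(NC(=O)Nc2cccc([N+](=O)[O-])c2)c2ccccc2n1`) gives > 25000 nM as a limit in the same way. Compound 3 (`Cc1cc(NC(=O)Nc2cnc3ccccc3c2)c2ccccc2n1`) also gives > 25000 nM as a limit. Compound 2 therefore has no numeric position and cannot be ranked against the other two (the limit of > 25000 nM in this assay, at which 3 of the 3 values shown sit).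

Compound 4 (`Cc1cc(NC(=O)Nc2cccc(C(F)(F)F)c2)c2ccccc2n1`) carries trifluoromethyl in place of nitro on an aromatic carbon, meta to a large group (trifluoromethyl in place of nitro on an aromatic carbon). Going by the values given here, no measured step sizes this change. With all three readings at the limit (the limit of > 25000 nM in this assay, at which 3 of the 3 values shown sit), no shift beyond the usual scatter is expected in this assay, and no direction can be assigned. The expected step (a number no higher from compound 2 to compound 4 (the limit leaves the size open)) is an estimate and is taken as no real change. For compound 4 the estimated value is 25000 nM with an expected range from 12000 nM to 50000 nM and a reading at the limit is the likely outcome.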

Compound 4, half-maximal effective concentration: 16000 nM
Compound 4: middle estimate off by 1.6-fold (0.19 log units), on the high side; the range from low to high includes it.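

Going by these compounds alone, at this position, meta to a large group, trifluoromethyl in place of nitro gives the only numeric reading so far: in this assay compound 4 gives 16000 nM. The change amounts to an at least 1.5-fold lower number from compound 2 to compound 4 (0.19 log units; that floor lies within the scatter), so the step is only a floor and does not by itself establish a real shift. The other compounds offer no number to set beside compound 4, only a limit of the assay: the limit of > 25000 nM in this assay, at which 3 of the 4 values shown sit.

From the compounds shown here alone, how far compound 2 truly lies from compound 4 remains open, since the size of that step is bounded on one side only. Also open, going by these compounds, is whether a reading inside the range of the assay is tied to trifluoromethyl at this place, or would also appear with an amine or a carboxylic acid there.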